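Phenyl to Phenethyl Chain Extension on Two Related Cores

The compounds below may be only part of what the source reports. "The series", "measured", "known", "first", "only" and "open" are said of these compounds alone.

Measured compounds:
compound 1, `CCCn1c(-c2ccco2)nc2c(N)nc(NCc3ccccc3)nc21`, 4610 nM
compound 2, `CCCn1c(-c2ccco2)nc2c(N)nc(NCCCc3ccccc3)nc21`, 8240 nM
compound 3, `CCCn1c(-c2ccco2)nc2c(NCc3ccccc3)ncnc21`, 1760 nM

All three were tested in a functional assay on CHO cells for antagonist activity at adenosine receptor A2b (Homo sapiens); on this read-out lower numbers stand for stronger inhibition and higher numbers for weaker inhibition. Compound 4, `CCCn1c(-c2ccco2)nc2c(NCCCc3ccccc3)ncnc21`, has not yet been measured. It differs from compound 3 by phenethyl in place of phenyl on a saturated chain carbon bound to a nitrogen on an aromatic ring. The same change, (phenethyl in place of phenyl on a saturated chain carbon bound to a nitrogen on an aromatic ring), links compound 1 to compound 2, where it gave a 1.8-fold higher number from compound 1 to compound 2 (0.25 log units; within the scatter). The difference between the cores of compound 1 and compound 3 is not broken down here; compound 3 simply gives the lowest of the three numbers. For compound 4 the step from compound 3 is expected to be about a 1.8-fold higher number from compound 3 to compound 4 (0.26 log units; within the scatter), because the matching step was a 1.8-fold higher number from compound 1 to compound 2 (0.25 log units; within the scatter) on the other core. Compound 4 is therefore estimated at 3200 nM, within a range of 1500 nM to 7000 nM.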

Compound 4, inhibition constant: 1870 nM
Estimate against measurement, compound 4: 1.7-fold (0.23 log units) above; the measured number falls inside the stated range.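

In this assay the change gave a 1.1-fold higher number from compound 3 to compound 4 (0.03 log units; within the scatter), the same reading of no step beyond the scatter as on the other core. Set side by side, the two steps do not differ: the same change on two cores in this assay, a 1.8-fold higher number (0.25 log units; within the scatter) from compound 1 to compound 2 and a 1.1-fold higher number (0.03 log units; within the scatter) from compound 3 to compound 4, 1.7-fold (0.23 log units) apart, within the scatter of two such steps. This shows that the change carried across these two cores without separating either pair of numbers beyond the scatter; it does not show that the change has any effect of its own, and two cores make no rule for the series.

The compounds shown leave open whether a chain longer than 3-phenylpropyl, or an amine or a carboxylic acid on the chain, would give a step beyond the scatter. They also leave open whether the two cores would still match with such groups.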